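Swapping the aryl ether in compound 3 for a methylimidazole

This account rests on a few compounds, and the source may have more. Where it says the series, first, only, none or still open, it means among the compounds named here.

Compounds measured so far in a functional assay for inhibition of sodium/hydrogen exchanger (Oryctolagus cuniculus); on this read-out lower numbers stand for stronger inhibition and higher numbers for weaker inhibition:
compound 1, `Cc1cc(C2CCCCC2)c(S(C)(=O)=O)cc1C(=O)N=C(N)N`, 22 nM
compound 2, `Cc1cc(-c2ccco2)c(S(C)(=O)=O)cc1C(=O)N=C(N)N`, 16 nM
compound 3, `Cc1cc(Oc2ccc(Cl)cc2)c(S(C)(=O)=O)cc1C(=O)N=C(N)N`, 13 nM

The three measured compounds share one core and differ only in the substituent on the aromatic carbon ortho to the methylsulfonyl group. Compound 3 stands at the lower edge of this small set, but every step leading to it stays within the scatter: a 1.7-fold lower number from compound 1 to compound 3 (0.23 log units; within the scatter) and a 1.2-fold lower number from compound 2 to compound 3 (0.09 log units; within the scatter). The step of a 1.4-fold lower number from compound 1 to compound 2 (0.14 log units; within the scatter) is likewise within the scatter. So far, then, a cyclohexyl, a furan-2-yl and a 4-chlorophenoxy group at this position have given numbers that cannot be told apart.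

Compound 4, `Cc1cn(-c2cc(C)c(C(=O)N=C(N)N)cc2S(C)(=O)=O)cn1`, is the next member to be measured. Its change from compound 3 is 4-methyl-1H-imidazol-1-yl in place of 4-chlorophenoxy on an aromatic carbon. For the measured compounds named here, the steps that bear on this are those at the same position, namely from compound 1 to compound 3 and from compound 2 to compound 3, both of which were within the scatter despite replacing quite different groups. Going by the values given here, on that basis no step beyond the scatter is expected in this assay, in either direction, although a five-membered heteroaromatic ring bonded through nitrogen has no direct precedent here, so the range is kept wide. Compound 4 is therefore estimated at 16 nM, with a range of 6 nM to 45 nM, an expected step of a 1.2-fold higher number from compound 3 to compound 4 (0.09 log units; within the scatter).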

Compound 4, half-maximal inhibitory concentration: 28 nM
For compound 4 the middle estimate is 1.8-fold (0.24 log units) below the measured one; low and high end bracket the measured number.
By their numbers in this assay, from the lowest: compounds 3, 2, 1 and 4 (each within the scatter of the next, the first and the last beyond it).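

In this assay, for the compounds shown here, the 4-methyl-1H-imidazol-1-yl group gives the only step at this position that lies beyond the scatter (a 2.2-fold higher number from compound 3 to compound 4 (0.33 log units; beyond the scatter)), so the substituent here is not wholly without consequence, although the step is modest. That separation holds only against the 4-chlorophenoxy group, for the same exchange made on the furan-2-yl and cyclohexyl compounds stays within the scatter (a 1.8-fold higher number from compound 2 to compound 4 (0.24 log units; within the scatter); a 1.3-fold higher number from compound 1 to compound 4 (0.10 log units; within the scatter)), and compound 4 cannot be told apart from either of them. Going by these compounds alone, nothing available here accounts for the one step that does stand out.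

What the compounds shown leave open is whether that step belongs to the imidazole ring itself or to its methyl group, a question that an unsubstituted 1H-imidazol-1-yl group would separate. Also open, as far as these compounds go, is how an amine such as piperidin-1-yl, a carboxylic acid or a plain phenoxy group without the chlorine would read at this place, and so whether the small gap seen here extends to a wider range of substituents.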